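The source may hold more compounds than are shown below. What is called first, only, known or untested is meant among the compounds shown, and "the series" means these compounds.

Of the compounds shown here, three sharing one core have so far been tested in a physicochemical assay for lipophilicity, using the shake flask method, measured as octanol-water partition, at pH 7.4; on this read-out lower numbers stand for lower lipophilicity and higher numbers for higher lipophilicity. Compound 1 `COc1cc(/C=C/C(=O)Nc2ccccc2)ccc1OCCCN(C)C` gives 1.55. Compound 2 `COc1cc(/C=C/C(=O)Nc2ccccc2)ccc1OCCCN1CCCCC1` gives 1.58, the second highest of the three numbers, with both neighbours within the scatter of it. Compound 3 `COc1cc(/C=C/C(=O)Nc2ccccc2)ccc1OCCCCN1CCCCC1` gives 1.61. Compound 4 `COc1cc(/C=C/C(=O)Nc2ccccc2)ccc1OCCCCCN(C)C` has not yet been measured; it differs from compound 2 by 2-(dimethylamino)ethyl in place of piperidin-1-yl on a saturated chain carbon, three bonds along the chain from an oxygen on an aromatic ring. This change resembles a return toward the dimethylamino of compound 1 together with a longer chain. Because a number 0.03 log units higher from compound 1 to compound 2 (within the scatter) and a number 0.03 log units higher from compound 2 to compound 3 (within the scatter) both stayed within the scatter, as did a number 0.06 log units higher from compound 1 to compound 3 (within the scatter), no step beyond the scatter is expected in this assay either. Compound 4 is therefore expected to give about 1.6, between 1.3 and 1.9, an estimated step of a number 0.02 log units higher from compound 2 to compound 4 (within the scatter).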

Compound 4, partition coefficient: 1.61
Beside the measured number, compound 4's estimate is 0.01 log units below it, within the range that was stated.
By their numbers in this assay, from the lowest: compounds 1, 2, 3 and 4 (each within the scatter of the next).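

In this assay, 2-(dimethylamino)ethyl in place of piperidin-1-yl gives a number 0.03 log units higher from compound 2 to compound 4 (within the scatter), showing that a group with no ring can stand in for the six-membered ring at this position without a step beyond the scatter. The two other comparisons agree: (dimethylamino)methyl in place of piperidin-1-yl, four bonds along the chain, gives no change at the digits printed from compound 3 to compound 4 (within the scatter), and 2-(dimethylamino)ethyl in place of dimethylamino gives a number 0.06 log units higher from compound 1 to compound 4 (within the scatter). Nothing available gives a reason for these small steps. Across these four compounds the amine end of the chain has varied only among simple amines, so it remains open whether a morpholine ring or a carboxylic acid there would stay within the scatter.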